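Swapping an Ether Chain for a Carbamate

The source may report more compounds than this note shows. Statements on the series, on what has been measured and on what is new or still open speak of the compounds shown alone.

Compound 1 `CC(C)=CCC/C(C)=C/COc1cc(=O)n(CCCO)c2c1CC(CC=C(C)C)C(C)(C)C2`: 10.6%
Compound 2 `CC(C)=CCC1Cc2c(OCCCOc3ccc(Cl)cc3)cc(=O)n(CCCO)c2CC1(C)C`: 22.7%

Within the data shown here, in a functional assay on PANC-1 cells (Homo sapiens) for inhibition, read by MTT assay, with a stated time of 24 h, tested at 10 uM (a lower number here means less inhibition, a higher number more inhibition at the concentration tested (going by the name of the read-out)), compound 2 gives 22.7%, the higher of the two numbers measured so far. Among the measured compounds shown here, compound 1 gives 10.6%, and the only measured step, a number 12.1 percentage points higher from compound 1 to compound 2 (beyond the scatter), comes from exchanging the group on the oxygen on the aromatic ring of the shared core.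

Compound 3 `COc1ccccc1NC(=O)Oc1cc(=O)n(CCCO)c2c1CC(CC=C(C)C)C(C)(C)C2` changes that same position once more: (2-methoxyphenyl)carbamoyl in place of 3-(4-chlorophenoxy)propyl on an oxygen on an aromatic ring. The measured step bears on it only loosely, since it shows that altering the group on this oxygen moves the number by a modest amount, but neither measured compound carries a carbamoyl group or a hydrogen-bond donor there. The step of a number 2.7 percentage points lower from compound 2 to compound 3 (within the scatter) is therefore expected to be small, in either direction, and not clearly beyond the scatter. Compound 3 is estimated to give 20%, with a range from 5% to 40%.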

Compound 3, a percentage reported as inhibition, at one concentration (the size of the read-out at that concentration, not a potency): 71.1%
Beside the measured number, compound 3's estimate is 51.1 percentage points below it; the measured number lies above the stated range.
By their numbers in this assay, from the lowest: compound 1; then compound 2; then compound 3.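

In this assay, the group on the oxygen on the aromatic ring can matter far more than the first pair suggested: (2-methoxyphenyl)carbamoyl gives a number 48.4 percentage points higher from compound 2 to compound 3 (beyond the scatter), and in place of the 3,7-dimethylocta-2,6-dien-1-yl chain it gives a number 60.5 percentage points higher from compound 1 to compound 3 (beyond the scatter), both large beside the modest a number 12.1 percentage points higher from compound 1 to compound 2 (beyond the scatter). The step from 3-(4-chlorophenoxy)propyl is the more telling one, as both groups have 11 heavy atoms and one six-membered aromatic ring, while the entering group brings a nitrogen, a double bond outside the ring and a hydrogen-bond donor. Nothing available here explains why this exchange raises the number so sharply.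

The compounds shown leave open whether the rise goes with the carbamoyl link or with the 2-methoxyphenyl ring. A carbamoyl carrying a plain phenyl or a methyl group, or a simple ether link to the same 2-methoxyphenyl ring, would separate the two.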